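The source may report more compounds than this note shows. Statements on the series, on what has been measured and on what is new or still open speak of the compounds shown alone.

Of the compounds shown here, two of one series have so far been tested in an ADME assay on Raji cells (Homo sapiens) for cytotoxicity, read by CellTiter-Glo and resazurin assay, with a stated time of 72 h; a higher number here means that more compound is needed for the effect, a lower number that less compound is needed. Compound 1 `CCOC(=O)CCCCCOc1cccc(CN(C(=O)c2ccc(-c3ccc4ccccc4c3)cc2)C(C)C)c1` gives only a limit there, > 26000 nM. Compound 2 `CCOC(=O)CCCCCOc1cccc(CN(C(=O)c2ccc(-c3cnc(OC)nc3OC)cc2)C(C)C)c1` likewise gives only a limit, > 26000 nM. The step that the two limits leave unreadable from compound 1 to compound 2 therefore has no readable size, since both values sit at the limit of > 26000 nM in this assay, at which 2 of the 2 values shown sit. Compound 3 `CCOC(=O)CCCCCOc1cccc(CN(C(=O)c2ccc(-c3ccoc3)cc2)C(C)C)c1` is the next member of the series, carrying the change (furan-3-yl in place of 2,4-dimethoxypyrimidin-5-yl on an aromatic carbon). Among the measured compounds shown here, the single measured step is unreadable, so it offers no direction for the step to compound 3; what the two measured compounds do show is that the shared core has twice stayed at the limit. For compound 3 the expectation is therefore that this assay again reports only the limit, with an estimate of 30000 nM and a range from 10000 nM to 100000 nM. This estimate means a step that the limit leaves unreadable from compound 2 to compound 3, which is expected to be no change beyond the scatter.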

Compound 3, half-maximal effective concentration: > 26000 nM
Compound 3 gave a limit, no number (the forecaster's own chance of this, stated with the estimate: 85%); the middle value does not contradict the limit.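

Compound 3, like compound 1 and compound 2, gives only a limit in this assay, so no step among these three compounds can be read: the limit of > 26000 nM in this assay, at which 3 of the 3 values shown sit. The compounds shown leave open whether naphthalen-2-yl, 2,4-dimethoxypyrimidin-5-yl and furan-3-yl differ at all in this assay.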